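Trifluoromethyl removal on the aryl group of compound 2

This account rests on a few compounds, and the source may have more. Where it says the series, first, only, none or still open, it means among the compounds named here.

Compound 1 `COc1cc(-c2nn(-c3cccc(NC(=O)c4ccc(Cl)c(C(F)(F)F)c4)c3)cc2-c2ccncc2)ccc1Cl` is the reference point of the set; in a functional assay on CCRF-CEM cells (Homo sapiens) for inhibition, read by sulforhodamine B assay, with a stated time of 48 h (a lower number here means that less compound is tolerated, a higher number that more compound is tolerated), compound 1 gives > 32500 nM, a limit of the assay rather than a number. Compound 3 `COc1cc(-c2nn(-c3cccc(NC(=O)Nc4ccc(Cl)c(C(F)(F)F)c4)c3)cc2-c2ccncc2)ccc1Cl` carries (4-chloro-3-(trifluoromethyl)phenyl)amino in place of 4-chloro-3-(trifluoromethyl)phenyl on a carbonyl carbon; in this assay compound 3 gives > 32500 nM, again a limit. The step that the two limits leave unreadable from compound 1 to compound 3 is not readable; both values sit at the limit of > 32500 nM in this assay, at which 2 of the 3 values shown sit. For the measured compounds named here, compound 2 `O=C(Nc1cccc(-n2cc(-c3ccncc3)c(-c3ccc(Cl)c(O)c3)n2)c1)Nc1cc(C(F)(F)F)cc(C(F)(F)F)c1` is the third member; in this assay compound 2 gives > 50000 nM, which is a limit and not a number, the single value at the limit of > 50000 nM in this assay, at which 1 of the 3 values shown sits. Going by the values given here, no compound in the set yields a measured number. Compound 4 `O=C(Nc1cccc(-n2cc(-c3ccncc3)c(-c3ccc(Cl)c(O)c3)n2)c1)Nc1cccc(C(F)(F)F)c1` differs from compound 2 by hydrogen in place of trifluoromethyl on an aromatic carbon. Among the compounds with values here, no measured step bears directly on this change, and the one measured step, from compound 1 to compound 3, is itself unreadable. No movement beyond the scatter can be foreseen, and compound 4 is expected to remain at a limit. Compound 4 is estimated at 60000 nM (range 20000 nM to 200000 nM). The implied step that the limit leaves unreadable from compound 2 to compound 4 is accordingly expected to be nil beyond the scatter.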

Compound 4, concentration lethal to 50% of the cells: > 32500 nM
Compound 4: a limit, no number (the forecaster's own chance of this, stated with the estimate: 85%); the middle value lies beyond the limit too.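

Compound 2 and compound 4 both stand at limits rather than numbers, so the step between them, hydrogen in place of trifluoromethyl, cannot be read. The compounds shown leave open whether this change, or any other in the series, shifts the lethal concentration at all.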